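The source may report more compounds than this note shows. Statements on the series, on what has been measured and on what is new or still open speak of the compounds shown alone.

Measured in a functional assay on DU-145 cells (Homo sapiens) for inhibition, read by trypan blue exclusion, with a stated time of 96 h; a higher number here means a weaker inhibitor of growth, a lower number a stronger inhibitor of growth:
- compound 1 `COc1ccccc1/C=C(/SCc1ccc(F)cc1)C(=O)c1ccc(Br)cc1`: 10000 nM
- compound 2 `COc1cc(OC)c(/C=C(/SCc2ccc(Cl)c(Cl)c2)C(=O)c2ccc(Cl)cc2)c(OC)c1`: 10000 nM

Compound 2 stands level with compound 1 at the digits shown, so the two cannot be told apart in this assay. They differ in more than one place, which means that neither value shows what any single change does.

The next compound is compound 3 `COc1cc(OC)c(/C=C(\C(=O)c2ccc(Cl)cc2)S(=O)(=O)c2ccc(C)cc2)c(OC)c1`. It carries (4-methylphenyl)sulfonyl in place of (3,4-dichlorobenzyl)sulfanyl on a double-bonded chain carbon bound to a carbonyl carbon and a double-bonded chain carbon. Among the measured compounds shown here, no measured pair shows this swap, so the expectation here is a cautious judgement and not a trend taken from data. A moderate move towards stronger growth inhibition seems more likely than a move towards weaker, although a result within the scatter of compound 2 would be no surprise. The expected change is a 3.3-fold lower number from compound 2 to compound 3 (0.52 log units; beyond the scatter), and this size is only an estimate. For compound 3 the estimated value is 3000 nM, with an expected range of 500 nM to 12000 nM.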

Compound 3, concentration for 50% growth inhibition: 25000 nM
The estimate for compound 3 lay 8.3-fold (0.92 log units) below the measured number, outside the stated range (above it).
By their numbers in this assay, from the lowest: compounds 1 and 2 (each within the scatter of the next); then compound 3.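

In this assay, putting (4-methylphenyl)sulfonyl in place of (3,4-dichlorobenzyl)sulfanyl on a double-bonded chain carbon bound to a carbonyl carbon and a double-bonded chain carbon gives a 2.5-fold higher number from compound 2 to compound 3 (0.40 log units; beyond the scatter) and so moves towards weaker growth inhibition, a modest step. This is the only pair shown that differs in one place, and it shows that the number in this assay responds to what this position carries. The response appears even though both groups have 10 heavy atoms and one six-membered aromatic ring, and no measurement shown here accounts for the difference.

The swap changes two things at once, the sulfur linkage and the group attached to it, so the step cannot be assigned to either one alone. A benzylsulfonyl group or a (4-methylphenyl)sulfanyl group at this position would separate those two changes, while a simple amine there would test a quite different kind of group.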